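Hexylsulfanyl in Place of Ethoxy: Cytotoxicity Outlook

This account rests on a few compounds, and the source may have more. Where it says the series, first, only, none or still open, it means among the compounds named here.

In an ADME assay on HFF cells (Homo sapiens) for cytotoxicity, with a stated time of 8 days (a lower number here means that less compound is tolerated, a higher number that more compound is tolerated), compound 1 `CCOc1nc(N)nc2c1ncn2/C=C1/CC1(CO)CO` gives > 300000 nM, which is a limit of the assay rather than a number. Compound 2 `Nc1nc(NC2CC2)c2ncn(/C=C3/CC3(CO)CO)c2n1` gives > 300000 nM in this assay, again only a limit. Among the measured compounds shown here, the single measured step, a step that the two limits leave unreadable from compound 1 to compound 2, therefore cannot be read in size, and all the evidence amounts to is the limit of > 300000 nM in this assay, at which 2 of the 2 values shown sit. Compound 3 `CCCCCCSc1nc(N)nc2c1ncn2/C=C1/CC1(CO)CO` carries hexylsulfanyl in place of ethoxy on an aromatic carbon. For the measured compounds named here, no measured step involves a hexylsulfanyl group, and the one step that alters the same aromatic carbon is unreadable, so no direction beyond the scatter can be drawn from it. Because a step that the two limits leave unreadable from compound 1 to compound 2 is unreadable and both measured compounds sit at the limit, compound 3 is expected to give 300000 nM, with a range from 100000 nM to 1000000 nM. The step of a number no higher from compound 1 to compound 3 (the limit leaves the size open) is accordingly estimated to remain within the scatter, and the most likely outcome is that this assay reports only a limit for compound 3 as well.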

Compound 3, half-maximal cytotoxic concentration: > 300000 nM
Compound 3 ended at the assay's limit; the forecaster's own chance of this, stated with the estimate: 70%; the middle value sits exactly at the limit.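

Compound 3 sits at the same assay limit as compound 1 and compound 2, so neither of its steps to those compounds can be read in size: the limit of > 300000 nM in this assay, at which 3 of the 3 values shown sit. The compounds shown leave open where the actual half-maximal cytotoxic concentrations lie in this assay, and whether ethoxy, cyclopropylamino and hexylsulfanyl on that aromatic carbon differ at all.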